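Three stereoisomers, one galactosaminidase, one more isomer expected

The compounds below may be only part of what the source reports. "The series", "measured", "known", "first", "only" and "open" are said of these compounds alone.

Compound 1 `O=C(O)[C@H]1NC[C@@H](O)[C@H](O)[C@H]1O` — 4.2%
Compound 2 `O=C(O)[C@@H]1NC[C@@H](O)[C@@H](O)[C@@H]1O` — 7.2%
Compound 3 `O=C(O)[C@@H]1NC[C@H](O)[C@@H](O)[C@@H]1O` — 3.4%

Three stereoisomers of one shared skeleton have been measured in an assay for inhibition of alpha-N-acetylgalactosaminidase (Gallus gallus), tested at 1000 uM; a higher number here means more inhibition at the concentration tested (going by the name of the read-out), a lower number less inhibition. Compound 1 gives 4.2%, compound 2 gives 7.2%, and compound 3 gives 3.4%. Compound 3 has the lowest of the three numbers, yet every gap between them lies within the scatter: a number 3 percentage points higher from compound 1 to compound 2 (within the scatter), a number 0.8 percentage points lower from compound 1 to compound 3 (within the scatter) and a number 3.8 percentage points lower from compound 2 to compound 3 (within the scatter). The pair of compound 2 and compound 3 is the closest model for what follows, because the fact that compounds 2 and 3 differ only in the configuration as drawn describes a single inverted stereocentre.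

Compound 4 `O=C(O)[C@@H]1NC[C@H](O)[C@@H](O)[C@H]1O` is the next isomer. the two compounds have the same atoms and bonds and differ only in configuration as drawn: 1 of 4 stereo elements differ; a stereocentre at a saturated ring carbon is drawn R in compound 3 and S in compound 4 The nearest measured step, a number 3.8 percentage points lower from compound 2 to compound 3 (within the scatter), stayed within the scatter, and the larger rearrangements did as well, so no movement beyond the scatter is expected in this assay. Compound 4 is estimated at 5%, with a range from 0% to 14%. This means an expected step of a number 1.6 percentage points higher from compound 3 to compound 4 (within the scatter).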

Compound 4, a percentage reported as inhibition, at one concentration (the size of the read-out at that concentration, not a potency): 4%
Compound 4: the middle estimate sits 1 percentage points above what was measured, and the stated range covers the measured number.
By their numbers in this assay, from the lowest: compounds 3, 4, 1 and 2 (each within the scatter of the next).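

In this assay, the inversion of this one stereocentre adds a second single-centre case to the set, and it gives a number 0.6 percentage points higher from compound 3 to compound 4 (within the scatter). The larger configurational differences read the same way, with a number 3.2 percentage points lower from compound 2 to compound 4 (within the scatter) and a number 0.2 percentage points lower from compound 1 to compound 4 (within the scatter), so compound 4 does not separate from any of the other three stereoisomers at this concentration. Configuration is the only variable in this step, and it leaves the number within the scatter: the fact that compounds 3 and 4 differ only in the configuration as drawn

With no step beyond the scatter, the role of this stereocentre in this assay remains unresolved. Also open, from the compounds shown here alone, is whether a hydroxymethyl group or a primary amide in place of the carboxylic acid would give a number that stands apart from these four.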